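This account rests on a few compounds, and the source may have more. Where it says the series, first, only, none or still open, it means among the compounds named here.

Measured so far:
- compound 1, `CC1=C(/C=C/C(=O)/C=C/c2ccc(C(F)(F)F)cc2)C(C)(C)CCC1`, in a functional assay on LNCaP cells (Homo sapiens) for cytotoxicity, read by MTT assay, with a stated time of 72 h (a lower number here means a stronger inhibitor, a higher number a weaker inhibitor), gives 9100 nM
- compound 2, `CC1=C(/C=C/C(=O)/C=C/c2ccc(F)cc2)C(C)(C)CCC1`, in this assay gives 7300 nM

Going by the values given here, compound 2 stands at the lowest of the two numbers recorded, but its only neighbour, compound 1, sits close: the step of a 1.2-fold lower number from compound 1 to compound 2 (0.10 log units; within the scatter) lies within the scatter of repeated measurements, so the two cannot be ranked against each other.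

Compound 3, `CC1=C(/C=C/C(=O)/C=C/c2ccc(-c3ccccc3)cc2)C(C)(C)CCC1`, has not yet been tested. It differs from compound 2 in one place: phenyl in place of fluoro on an aromatic carbon. Among the compounds with values here, no measured step covers this exchange directly. Within the data shown here, the single step available, a 1.2-fold lower number from compound 1 to compound 2 (0.10 log units; within the scatter), exchanges one small substituent for another on the same aromatic carbon and moves the number only within the scatter; it says nothing about what a larger substituent does there. The expectation for compound 3 therefore rests mainly on the observation that compound 1 and compound 2 gave numbers close to each other in this assay, and a step of size a 1.2-fold lower number from compound 2 to compound 3 (0.09 log units; within the scatter) is expected, which would again fall within the scatter. Compound 3 is estimated at 6000 nM, with a plausible range from 2000 nM to 18000 nM.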

Compound 3, half-maximal inhibitory concentration: 14800 nM
The estimate for compound 3 lay 2.5-fold (0.39 log units) below the measured number, and the stated range covers the measured number.
By their numbers in this assay, from the lowest: compounds 2, 1 and 3 (each within the scatter of the next, the first and the last beyond it).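

At this aromatic carbon, para to a large group, phenyl brings 6 heavy atoms and a ring where fluoro brought 1 heavy atom and no ring. In this assay, going by these compounds alone, that exchange gives a 2.0-fold higher number from compound 2 to compound 3 (0.31 log units; beyond the scatter) and is the first step to pass the scatter, though only modestly, so this position does respond to the substituent placed on it. The exchange of trifluoromethyl for phenyl at the same carbon gives a 1.6-fold higher number from compound 1 to compound 3 (0.21 log units; within the scatter) and stays within the scatter, so compound 1 and compound 3 cannot be ranked, and compound 1 goes against any simple reading in which phenyl alone sets the number apart from the smaller groups.

The compounds shown leave open whether a group of another kind on this carbon, such as an amine, a carboxylic acid or a longer chain, would carry the number well outside the range these three span, in either direction. They also offer no account of why the step from fluoro to phenyl goes the way it does, as no supporting evidence bears on it.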